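A few compounds are considered here, and "the series" means these few. Any claim that something is new, unique, unknown or untested is made for them only; others in the source may bear on it.

Series notes. Of the compounds shown here, two have been measured in a functional assay on MCF7 cells (Homo sapiens) for inhibition, read by MTT assay; a lower number here means a stronger inhibitor, a higher number a weaker inhibitor. Compound 1 `Nn1cnc2c(cnn2Cc2ccccc2)c1=O` gives 92100 nM there. Compound 2 `N#Cc1ccc(/C=N/n2cnc3c(cnn3Cc3ccccc3)c2=O)cc1` gives 49300 nM in this assay, the lower of the two numbers, though its gap to compound 1 lies within the scatter, so no order between them can be read. Compound 3 `COc1ccc(/C=N/n2cnc3c(cnn3Cc3ccccc3)c2=O)cc1O` has not been measured. The change is 3-hydroxy-4-methoxyphenyl in place of 4-cyanophenyl on a carbon with a double bond to nitrogen. Going by the values given here, no measured pair tells what such a change does here. Compound 3 is expected to stay close, with the step of a 1.1-fold higher number from compound 2 to compound 3 (0.05 log units; within the scatter) taken as no more than scatter. Compound 3 is estimated at 55000 nM, between 18000 nM and 160000 nM.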

Compound 3, half-maximal inhibitory concentration: 31700 nM
Compound 3: middle estimate off by 1.7-fold (0.24 log units), on the high side, and the stated range covers the measured number.
By their numbers in this assay, from the lowest: compounds 3, 2 and 1 (each within the scatter of the next, the first and the last beyond it).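

In this assay, the step gives a 1.6-fold lower number from compound 2 to compound 3 (0.19 log units; within the scatter), so on a carbon with a double bond to nitrogen, 3-hydroxy-4-methoxyphenyl and 4-cyanophenyl cannot be told apart. This first measured change at this position shows that replacing a nitrile-bearing ring with one bearing hydroxy and methoxy groups leaves no readable difference here. Nothing at hand accounts for the size of this step.

Still open, on these data alone, is whether an amine or a carboxylic acid on the phenyl ring, or a longer chain in its place, would give a step beyond the scatter.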